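A few compounds are considered here, and "the series" means these few. Any claim that something is new, unique, unknown or untested is made for them only; others in the source may bear on it.

Compound 2 `CCOc1ccccc1-c1ccc(-c2nc3cnccc3c(N[C@H](CC)C(=O)N(C)C)c2C#N)cc1` stands highest of the three measured compounds in a physicochemical assay for lipophilicity, read by HPLC, at pH 7.5 (a lower number here means a more polar compound, a higher number a more lipophilic compound), at 3.7, while compound 1 `CCOc1ccccc1-c1ccc(-c2nc3cnccc3c(NC(C)C(=O)O)c2C#N)cc1` gives 2.1 and compound 3 `CCOc1ccccc1-c1ccc(-c2nc3cnccc3c(C[C@H](C)C(=O)O)c2C#N)cc1` gives 2.2. Compound 4 `CCOc1ccccc1-c1ccc(-c2nc3cnccc3c(N[C@H](CC)C(=O)NS(=O)(=O)C3CC3)c2C#N)cc1` differs from compound 2 by (cyclopropylsulfonyl)amino in place of dimethylamino on a carbonyl carbon, which turns dimethylcarbamoyl into (cyclopropylsulfonyl)carbamoyl. Among the compounds with values here, no measured compound carries this group, so the nearest guides are indirect. Two large steps separate the dimethylcarbamoyl compound from the carboxy compounds, a number 1.60 log units higher from compound 1 to compound 2 (beyond the scatter) and a number 1.50 log units lower from compound 2 to compound 3 (beyond the scatter), whereas a number 0.10 log units higher from compound 1 to compound 3 (within the scatter) stays within the scatter. If the new group tracks the carboxy compounds, a large fall is expected, and the estimated step is a number 1.10 log units lower from compound 2 to compound 4 (beyond the scatter). The estimate for compound 4 is 2.6, within an expected range of 2 to 3.3.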

Compound 4, distribution coefficient: 2.3
Estimate against measurement, compound 4: 0.30 log units above; the measured number falls inside the stated range.
By their numbers in this assay, from the lowest: compounds 1, 3 and 4 (each within the scatter of the next); then compound 2.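

Within the data shown here, the change from dimethylamino to (cyclopropylsulfonyl)amino on the carbonyl carbon gives a number 1.40 log units lower from compound 2 to compound 4 (beyond the scatter) in this assay, so a large step at this place does not require a carboxy group, the only group behind such steps among the earlier compounds. With a number 0.20 log units higher from compound 1 to compound 4 (within the scatter), the larger group with its three-membered ring stays level with the carboxy group of compound 1. Nothing measured here accounts for either step. The compounds shown leave open whether a methylsulfonyl or phenylsulfonyl group on the same nitrogen, or a primary amide, would read like compound 4 or compound 2.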